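The compounds below may be only part of what the source reports. "The series", "measured", "known", "first", "only" and "open" are said of these compounds alone.

Three compounds of a shared core were tested in a functional assay on cells (Lymphocyte, Homo sapiens), read by a luciferase reporter and ATP content, with a stated time of 48 h, tested at 1 uM; a higher number here means a weaker effect of the compound at the concentration tested, a lower number a stronger effect. Compound 1 `Cc1nc(OC2CCC2)nc(N2CCC2)c1O` gives 101% in this assay. Compound 3 `Cc1nc(OC2CCC2)nc(OC2CCC2)c1O` gives 101% in this assay, and the step from compound 1 to compound 3 is no change at the digits printed from compound 1 to compound 3 (within the scatter), the change being (cyclobutyloxy in place of azetidin-1-yl on an aromatic carbon). Compound 2 `CCCCCCCCCCCCCCc1nc(OC2CCC2)nc(N2CCC2)c1O` gives 109% in this assay; the difference between its core and that of compound 1 is not broken down here, and the values of compound 1 and compound 2 lie within the scatter of each other.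

Compound 4 `CCCCCCCCCCCCCCc1nc(OC2CCC2)nc(OC2CCC2)c1O` has not yet been measured in this assay. It differs from compound 2 by cyclobutyloxy in place of azetidin-1-yl on an aromatic carbon. This is the same kind of change as that from compound 1 to compound 3, though the place is meta to a large group in compound 2 rather than meta to a methyl group. Because no change at the digits printed from compound 1 to compound 3 (within the scatter) was flat, the step from compound 2 to compound 4 is expected to be a number 5 percentage points lower from compound 2 to compound 4 (within the scatter). Compound 4 is therefore estimated at 104%, between 92% and 116%.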

Compound 4, a percentage reported as activity, at one concentration (the size of the read-out at that concentration, not a potency): 99%
The estimate for compound 4 lay 5 percentage points above the measured number; low and high end bracket the measured number.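

In this assay the new step is a number 10 percentage points lower from compound 2 to compound 4 (within the scatter). Set beside the earlier step, cyclobutyloxy in place of azetidin-1-yl gives steps on the two cores that cannot be told apart: the same change on two cores in this assay, no change at the digits printed (within the scatter) from compound 1 to compound 3 and a number 10 percentage points lower (within the scatter) from compound 2 to compound 4, 10 percentage points apart, within the scatter of two such steps

This shows that the change carried from the core of compound 1 to the core of compound 2 with no difference beyond the scatter, at the one concentration tested; it does not show that the change would carry the same way to a third core, nor does a pair of steps within the scatter establish a rule for the series.

The compounds shown leave open whether a different group in that place, such as dimethylamino or a carboxylic acid, would shift the read-out in this assay. They also leave open how the same change would read on a core carrying a chain of another length, such as hexyl.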